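A few compounds are considered here, and "the series" means these few. Any claim that something is new, unique, unknown or untested is made for them only; others in the source may bear on it.

Measured so far in a physicochemical assay for solubility; a higher number here means a more soluble compound, a lower number a less soluble compound:

- compound 1 `CCOc1ccc2c(c1)C=CN(C)C(=O)C2C` gives >= 120 ug/mL as a limit
- compound 2 `CCOc1ccc2c(c1)C(c1cn[nH]c1)=CN(C)C(=O)[C@@H]2C` gives >= 115 ug/mL as a limit
- compound 3 `CCOc1ccc2c(c1)C(c1c[nH]cn1)=CN(C)C(=O)[C@@H]2C` gives >= 131 ug/mL as a limit

Compound 1 is known only through the limit >= 120 ug/mL and offers no exact number to start from. Compound 4 `CCOc1ccc2c(c1)C(n1ccnc1)=CN(C)C(=O)C2C` differs from compound 1 by one change, (1H-imidazol-1-yl in place of hydrogen on a double-bonded ring carbon), with 1H-imidazol-1-yl in place of hydrogen on a double-bonded ring carbon.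

Among the compounds with values here, the only measured step, a step that the two limits leave unreadable from compound 2 to compound 3, has no readable size. Compound 2, with 1H-pyrazol-4-yl on a double-bonded ring carbon, still reads as the limit >= 115 ug/mL and gives no number. Compound 3, with 1H-imidazol-4-yl there, likewise reads as the limit >= 131 ug/mL and gives no number.

No step beyond the scatter is therefore expected in this assay, and no direction can be read from these limits. The expected change is a number no higher from compound 1 to compound 4 (the limit leaves the size open) and may well remain unreadable. Compound 4 is estimated at 120 ug/mL with an expected range of 60 ug/mL to 150 ug/mL for the measurement.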

Compound 4, solubility: >= 65 ug/mL
Compound 4: a limit, no number; the forecaster's own chance of this, stated with the estimate: 70%; the middle value lies beyond the limit too.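

In this assay, compound 1 and compound 4 are both known only as limits, not numbers, and no new step can be read between them. The compounds shown leave open whether 1H-imidazol-1-yl in place of hydrogen on a double-bonded ring carbon changes solubility at all.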